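Removing the (1-bromoethenyl)carbonyl group from compound 2

The source may hold more compounds than are shown below. What is called first, only, known or untested is meant among the compounds shown, and "the series" means these compounds.

In an ADME assay on CCRF-CEM cells (Homo sapiens) for antiproliferative activity, with a stated time of 48 h (on this read-out lower numbers stand for stronger inhibition and higher numbers for weaker inhibition), compound 2 `C=C(Br)C(=O)Nc1ccc(/C=C/C(=O)c2cc(OC)c(OC)c(OC)c2)cc1` gives 1100 nM as its result. Compound 1 `C=C(Br)C(=O)Nc1ccc(/C=C/C(=O)c2ccc(Cl)cc2)cc1` gives 950 nM and lies within the scatter of compound 2. Compound 3 `Nc1ccc(/C=C/C(=O)c2ccc(Cl)cc2)cc1` gives 21000 nM and stands far above both.

Compound 4 `COc1cc(C(=O)/C=C/c2ccc(N)cc2)cc(OC)c1OC` has not yet been measured. Its difference from compound 2 reads (hydrogen in place of (1-bromoethenyl)carbonyl on a nitrogen on an aromatic ring). In short, it has hydrogen in place of (1-bromoethenyl)carbonyl on a nitrogen on an aromatic ring.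

Going by the values given here, only one measured step bears on this change. The same exchange, made on compound 1, gives a 22-fold higher number from compound 1 to compound 3 (1.34 log units; beyond the scatter) and is large and beyond the scatter. That single pair cannot show whether a step of this size carries over to a compound with a different remainder, so the expectation is uncertain. A similarly large rise is still expected, with an 18-fold higher number from compound 2 to compound 4 (1.26 log units; beyond the scatter) as the estimated step. Compound 4 is estimated in this assay at 20000 nM with 6000 nM to 50000 nM as its expected range.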

Compound 4, half-maximal inhibitory concentration: 2500 nM
Beside the measured number, compound 4's estimate is 8.0-fold (0.90 log units) above it; measured number outside the range, below it.
By their numbers in this assay, from the lowest: compounds 1 and 2 (each within the scatter of the next); then compound 4; then compound 3.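

With the core of compound 2, removing the (1-bromoethenyl)carbonyl group from the nitrogen gives a 2.3-fold higher number from compound 2 to compound 4 (0.36 log units; beyond the scatter), a modest step, though still beyond the scatter. The earlier pair alone had shown only a large step, so the size of this exchange is now seen to differ with the remainder of the molecule. The group counts for far more on the core of compound 1 than on the core of compound 2, and the two steps do not agree: the same change on two cores in this assay, a 22-fold higher number (1.34 log units; beyond the scatter) from compound 1 to compound 3 and a 2.3-fold higher number (0.36 log units; beyond the scatter) from compound 2 to compound 4, 9.7-fold (0.99 log units) apart, beyond the scatter of two such steps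

The compounds shown leave open whether the bromine or the rest of the group accounts for the step on either core. An acetyl group or an unbrominated propenoyl group on the same nitrogen would bear on that question, and a third core would show how widely the size of the step varies.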